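Swapping Methoxy for Trifluoromethyl on the Outer Ring

The source may report more compounds than this note shows. Statements on the series, on what has been measured and on what is new or still open speak of the compounds shown alone.

Three urea compounds built on one shared core have been tested in an assay on isolated protein for inhibition of serine/threonine-protein kinase PLK1 (Homo sapiens), read by radiometric assay and 33P incorporation, with a stated time of 40 min, tested at 20 uM, in the presence of a further agent that is not named here; on this read-out higher numbers stand for more inhibition at the one concentration tested (going by the name of the read-out) and lower numbers for less inhibition. Compound 1 `CCNc1cc(-c2ccc(NC(=O)Nc3ccc(OC)cc3)cc2C(F)(F)F)ccn1` gives 62.1%, compound 2 `CCNc1cc(-c2ccc(NC(=O)Nc3ccc(OC)cc3)cc2OC)ccn1` gives 31.1%, and compound 3 `CCNc1cc(-c2ccc(NC(=O)Nc3ccc(OC)cc3)cc2F)ccn1` gives 47.1%. The change trifluoromethyl in place of methoxy on an aromatic carbon brings a number 31 percentage points higher from compound 2 to compound 1 (beyond the scatter). The change fluoro in place of methoxy on an aromatic carbon brings a number 16 percentage points higher from compound 2 to compound 3 (beyond the scatter), and the remaining pair shows a number 15 percentage points lower from compound 1 to compound 3 (beyond the scatter).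

Compound 4 `CCNc1cc(-c2ccc(NC(=O)Nc3ccc(C(F)(F)F)cc3)cc2F)ccn1` has not yet been measured. It differs from compound 3 by trifluoromethyl in place of methoxy on an aromatic carbon. This is the same kind of change as trifluoromethyl in place of methoxy on an aromatic carbon, yet not the same: in compound 1 the new group stands ortho to a 2-(ethylamino)pyridin-4-yl group and meta to a large group, whereas in compound 4 it stands para to a large group. The two cores also differ, by fluoro in place of methoxy on an aromatic carbon.

Within the data shown here, for compound 4 the expected step is a number 7.9 percentage points higher from compound 3 to compound 4 (within the scatter), smaller than the earlier one, because a number 31 percentage points higher from compound 2 to compound 1 (beyond the scatter) was measured at a different place and no measured pair shows this change at the new place. Compound 4 is therefore estimated at 55%, with a range from 35% to 75%.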

Compound 4, a percentage reported as inhibition, at one concentration (the size of the read-out at that concentration, not a potency): 55.8%
Compound 4: middle estimate off by 0.8 percentage points, on the low side; the range from low to high includes it.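

In this assay, the swap of methoxy for trifluoromethyl, here 4-methoxyphenyl to 4-(trifluoromethyl)phenyl, brings a number 8.7 percentage points higher from compound 3 to compound 4 (within the scatter), so at this place its effect cannot be told apart from no change. The size of the step therefore did not carry over from the earlier place and core, as the two steps set side by side show: the same change on two cores in this assay, a number 31 percentage points higher (beyond the scatter) from compound 2 to compound 1 and a number 8.7 percentage points higher (within the scatter) from compound 3 to compound 4, 22.3 percentage points apart, beyond the scatter of two such steps What this does not show is which difference matters, since the place of the swap and the rest of the core both differ between the two pairs, and two pairs cannot pull those apart.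

The compounds shown leave open what an amine, a carboxylic acid or a nitrile would give in place of the trifluoromethyl of compound 4. Also open, on these data alone, is how the core of compound 1 would respond to the same swap at this second place, which would test the place with the core held fixed.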